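Exchanging bromo for chloro across two related cores

The source may hold more compounds than are shown below. What is called first, only, known or untested is meant among the compounds shown, and "the series" means these compounds.

Of the compounds shown here, three have been measured in a functional assay on MT4 cells (Homo sapiens) for cytotoxicity; on this read-out lower numbers stand for stronger inhibition and higher numbers for weaker inhibition. Compound 1 `N#Cc1c(N)cccc1Sc1ccccc1Cl` and compound 2 `N#Cc1c(N)cccc1Sc1ccccc1Br` share one core and differ only in a halogen. In this assay compound 1 gives 33000 nM, while compound 2 gives 41000 nM. The change between them, (chloro in place of bromo on an aromatic carbon), produced a 1.2-fold lower number from compound 2 to compound 1 (0.09 log units; within the scatter). Compound 3 `Cc1cc(Br)cc(S(=O)(=O)c2cccc(N)c2C#N)c1` is built on a different core, and in this assay compound 3 gives 133000 nM, the highest number of the three, with the numbers of compound 1 and compound 2 both lying beyond the scatter below it. The difference between the two cores is not broken down here.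

Compound 4 `Cc1cc(Cl)cc(S(=O)(=O)c2cccc(N)c2C#N)c1` has not yet been measured. It is related to compound 3 by chloro in place of bromo on an aromatic carbon. Going by the values given here, this is the same kind of change as the one from compound 2 to compound 1, but not the same: in the earlier pair the halogen sits ortho to a large group, whereas in compound 3 and compound 4 it sits meta to a large group and meta to a methyl group. Since the earlier step, a 1.2-fold lower number from compound 2 to compound 1 (0.09 log units; within the scatter), stayed within the scatter, a step of similar size is expected here, namely a 1.1-fold lower number from compound 3 to compound 4 (0.04 log units; within the scatter). Because compound 3 gives 133000 nM, compound 4 is estimated at 120000 nM, with a likely range from 60000 nM to 250000 nM.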

Compound 4, half-maximal inhibitory concentration: > 200000 nM
Compound 4 was reported as a limit; the forecaster's own chance of this, stated with the estimate: 20%; at least 1.6-fold (0.22 log units) between middle value and limit.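

In this assay compound 4 gives > 200000 nM, which is a limit of the assay and not a number, and this is the only compound shown that is reported in this way: the limit of > 200000 nM in this assay, at which 1 of the 4 values shown sits. On the second core, the exchange of bromo for chloro gives an at least 1.5-fold higher number from compound 3 to compound 4 (0.17 log units; that floor lies within the scatter), so the step has only a floor, and it cannot be told whether the true step lies within or beyond the scatter. Set beside the step on the first core, the result shows that the same exchange has now been read on two cores, but it does not show whether the change carries over from one to the other, since neither agreement nor disagreement between the two steps can be established: the same change on two cores in this assay, a 1.2-fold lower number (0.09 log units; within the scatter) from compound 2 to compound 1 and an at least 1.5-fold higher number (0.17 log units; that floor lies within the scatter) from compound 3 to compound 4; the limit leaves it open whether they differ.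

The compounds shown leave open how a fluoro, a methoxy or an amine in place of the halogen would read on either core. Going by these compounds alone, they also leave open how the two cores compare when each carries the same halogen in the same place on its ring, so the exchange of bromo for chloro remains the only change that can be followed here.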